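Swapping a Bromophenyl for a Chloropyridinyl on the Benzylamine

The source may report more compounds than this note shows. Statements on the series, on what has been measured and on what is new or still open speak of the compounds shown alone.

Among the compounds with values here, compound 2 `O=C(Nc1ccc(NCc2ccc(Br)cc2)cc1Cl)c1cc(Cl)ccc1O` holds the higher of the two numbers measured so far: in an ADME assay on A549 cells (Homo sapiens) for cytotoxicity, read by resazurin assay, with a stated time of 48 h (on this read-out higher numbers stand for lower toxicity in this test and lower numbers for higher toxicity in this test), compound 2 gives 40900 nM. Within the data shown here, compound 1 `CC(C)Nc1ccc(NC(=O)c2cc(Cl)ccc2O)c(Cl)c1` gives 11000 nM, and the only measured step, a 3.7-fold higher number from compound 1 to compound 2 (0.57 log units; beyond the scatter), exchanged a small alkyl group for a whole benzyl group. Compound 3 `O=C(Nc1ccc(NCc2cccnc2Cl)cc1Cl)c1cc(Cl)ccc1O` differs from compound 2 by 2-chloropyridin-3-yl in place of 4-bromophenyl on a saturated chain carbon bound to a nitrogen on an aromatic ring. No measured step exchanges one aromatic ring for another at this place, so nothing shown speaks directly to it. The expected step of a 1.2-fold lower number from compound 2 to compound 3 (0.07 log units; within the scatter) is therefore estimated to stay within the scatter. Compound 3 is estimated at 35000 nM, with a range from 15000 nM to 80000 nM.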

Compound 3, half-maximal cytotoxic concentration: 101000 nM
The estimate for compound 3 lay 2.9-fold (0.46 log units) below the measured number; the measured number lies above the stated range.
By their numbers in this assay, from the lowest: compound 1; then compound 2; then compound 3.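

In this assay, within the data shown here, 2-chloropyridin-3-yl in place of 4-bromophenyl gives a 2.5-fold higher number from compound 2 to compound 3 (0.39 log units; beyond the scatter), so which aromatic ring sits at this place matters, not only that a ring is there. Measured against the small isopropyl group, (2-chloropyridin-3-yl)methyl gives a 9.2-fold higher number from compound 1 to compound 3 (0.96 log units; beyond the scatter), which here means lower toxicity in this test. Nothing available explains why the ring exchange moved the number.

On these data alone, compound 3 changes the ring nitrogen and the halogen together, so which of them goes with the higher number stays open. A pyridine ring carrying no chlorine, or a chlorophenyl ring, would separate the two.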